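Working notes on the phenyl to dichlorophenyl step

The compounds below may be only part of what the source reports. "The series", "measured", "known", "first", "only" and "open" are said of these compounds alone.

Measured so far:
compound 1 `Cc1cc(=O)oc2cc(OCCCn3cc(CNC(=O)CCCCC4CCSS4)nn3)ccc12` gives 64.6%
compound 2 `O=C(CCCCC1CCSS1)NCc1cn(CCCOc2ccc3cc(C(=O)O)c(=O)oc3c2)nn1` gives 57%
compound 3 `O=C(CCCCC1CCSS1)NCc1cn(CCCOc2ccc3cc(-c4ccccc4)c(=O)oc3c2)nn1` gives 29.8%

In a functional assay on PC-12 cells (Rattus norvegicus) for cytotoxicity, read by MTT assay, with stated times of 3 h and 2 h, tested at 5 uM (a higher number here means a stronger effect of the compound at the concentration tested, a lower number a weaker effect), compound 3 holds the lowest of the three numbers; compound 2 is nearest, separated by the step of a number 27.2 percentage points lower from compound 2 to compound 3 (beyond the scatter), and compound 1 stands further above it. Compound 4 `O=C(CCCCC1CCSS1)NCc1cn(CCCOc2ccc3cc(-c4ccc(Cl)c(Cl)c4)c(=O)oc3c2)nn1` differs from compound 3 by 3,4-dichlorophenyl in place of phenyl on an aromatic carbon. Among the compounds with values here, no measured pair changes the group at this place in that way; the one known step exchanges carboxy for phenyl and is of a different kind, so it gives no direct guide. Carrying the number of compound 3 over, the expected step is a number 1.8 percentage points lower from compound 3 to compound 4 (within the scatter), not beyond the scatter. Compound 4 is therefore estimated at 28%, with a range from 12% to 46%.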

Compound 4, a percentage reported as activity, at one concentration (the size of the read-out at that concentration, not a potency): 44.7%
The estimate for compound 4 lay 16.7 percentage points below the measured number; the range from low to high includes it.
By their numbers in this assay, from the lowest: compound 3; then compound 4; then compounds 2 and 1 (each within the scatter of the next).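

Within the data shown here, compound 3 and compound 4 give the first comparison at this position between two carbon-only aromatic rings, and substitution on the phenyl proves able to move the read-out in this assay: there is a number 14.9 percentage points higher from compound 3 to compound 4 (beyond the scatter) with 3,4-dichlorophenyl in place of phenyl. The dichlorophenyl group does not reach the carboxy compound, with a number 12.3 percentage points lower from compound 2 to compound 4 (beyond the scatter) in the same assay. No available evidence bears on the origin of either step. Still open, on these data alone, is whether a phenyl with a single chlorine gives a number nearer compound 3 or compound 4. Also open, as far as these compounds go, is how a phenyl carrying a methoxy or an amine in place of the chlorines would read.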